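Methoxy for fluoro on the phenoxy ring of compound 2

This account rests on a few compounds, and the source may have more. Where it says the series, first, only, none or still open, it means among the compounds named here.

Measured compounds:
compound 1 `Cc1nn(C)c(Oc2ccc(F)cc2)c1/C=N\OCc1c(Cl)c(-c2ccc(F)cc2)nn1C`, 80%
compound 2 `Cc1nn(C)c(Oc2ccc(F)cc2)c1/C=N\OCc1c(Cl)c(-c2ccc(Cl)cc2)nn1C`, 80%

In a functional assay on SMMC-7721 cells (Homo sapiens) for inhibition, read by MTT assay, with a stated time of 72 h, tested at 25 uM (on this read-out lower numbers stand for less inhibition and higher numbers for more inhibition at the one concentration tested (going by the name of the read-out)), compound 1 gives 80%. Compound 2 `Cc1nn(C)c(Oc2ccc(F)cc2)c1/C=N\OCc1c(Cl)c(-c2ccc(Cl)cc2)nn1C` stands level with compound 1 at the digits printed; in this assay compound 2 gives 80%. Among the compounds with values here, the only measured step, no change at the digits printed from compound 1 to compound 2 (within the scatter), put chloro in place of fluoro on an aromatic carbon of the aryl group on the shared core and lay within the scatter.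

Compound 3 `COc1ccc(Oc2c(/C=N\OCc3c(Cl)c(-c4ccc(Cl)cc4)nn3C)c(C)nn2C)cc1` differs from compound 2 by methoxy in place of fluoro on an aromatic carbon. Within the data shown here, no measured step touches this ring, so the single step on record bears on it only indirectly: it shows that one change at an aromatic carbon elsewhere left this assay unchanged. The expectation for compound 3 is therefore a step of a number 5 percentage points lower from compound 2 to compound 3 (within the scatter), with no change beyond the scatter most likely. Compound 3 is estimated at 75%, in the range 55% to 90%.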

Compound 3, a percentage reported as inhibition, at one concentration (the size of the read-out at that concentration, not a potency): 80%
Compound 3: middle estimate off by 5 percentage points, on the low side; low and high end bracket the measured number.
By their numbers in this assay, from the lowest: compounds 1, 2 and 3 (each within the scatter of the next).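

With 4-methoxyphenoxy in place of 4-fluorophenoxy, the reading in this assay shows no change at the digits printed from compound 2 to compound 3 (within the scatter) and gives this ring a measured step of its own. Within the data shown here, until now, the only step on record concerned the aryl group at the other end of the molecule, so nothing had been read at this place, para to a large group. Here, a change that brings in one more heavy atom and a hydrogen-bond acceptor leaves the read-out level at the one concentration tested. Nothing measured here accounts for this result.

The compounds shown leave open whether this place would stay as level with an amine or a carboxylic acid there, or with a longer chain such as butoxy. They also leave open whether differences among these three compounds would appear at other concentrations.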